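Replacing a Benzoyl Group at the Amine Nitrogen

A few compounds are considered here, and "the series" means these few. Any claim that something is new, unique, unknown or untested is made for them only; others in the source may bear on it.

Measured compounds:
compound 1 `COC(=O)CC(=O)NC1=CS(=O)(=O)O[C@@]12[C@@H](CO[Si](C)(C)C(C)(C)C)O[C@@H](n1cc(C)c(=O)n(C)c1=O)[C@@H]2O[Si](C)(C)C(C)(C)C` — 400000 nM
compound 2 `Cc1cn([C@@H]2O[C@H](CO[Si](C)(C)C(C)(C)C)[C@@]3(OS(=O)(=O)C=C3NC(=O)c3ccccc3)[C@H]2O[Si](C)(C)C(C)(C)C)c(=O)n(C)c1=O` — >= 3200 nM

Two compounds share a core and differ at a carbonyl carbon. In a functional assay on HEL cells (Homo sapiens) for cytotoxicity, read by microscopy (on this read-out lower numbers stand for higher toxicity in this test and higher numbers for lower toxicity in this test), compound 1 gives 400000 nM. For compound 2 in this assay the assay reports only a limit, >= 3200 nM. The step that the limit leaves unreadable from compound 1 to compound 2 therefore cannot be sized, because of the limit of >= 3200 nM in this assay, at which 1 of the 2 values shown sits. Compound 3 `Cc1cn([C@@H]2O[C@H](CO[Si](C)(C)C(C)(C)C)[C@@]3(OS(=O)(=O)C=C3NCC(=O)C(N)=O)[C@H]2O[Si](C)(C)C(C)(C)C)c(=O)n(C)c1=O` is not yet measured. Against compound 2 it shows ((carbamoylcarbonyl)methyl in place of benzoyl on an amine nitrogen). Within the data shown here, no measured step covers a change on the amine nitrogen, and the only step between measured compounds is unreadable, so the measured data give no direction or size for this change in this assay. Compound 1 sits far up the scale, while compound 2 stands only at a limit. On this basis compound 3 is expected to give 100000 nM, within 10000 nM to 400000 nM. This estimate means an expected step that the limit leaves unreadable from compound 2 to compound 3.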

Compound 3, minimum cytotoxic concentration: >= 16000 nM
Compound 3: no number, only a limit; the forecaster's own chance of this, stated with the estimate: 50%; the middle value is on the limit's open side.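

In this assay, among these compounds, compound 3 gives only a limit, >= 16000 nM, so no new step linking it to compound 1 or compound 2 can be read. The compounds shown leave open the direction and size of any change in this assay when (carbamoylcarbonyl)methyl replaces benzoyl on the amine nitrogen.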